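The compounds below may be only part of what the source reports. "The series", "measured", "known", "first", "only" and "open" are said of these compounds alone.

Working notes on the series: in a functional assay on SPCA2 cells (Homo sapiens) for cytotoxicity, read by MTT assay, with a stated time of 2 days (on this read-out higher numbers stand for weaker inhibition and lower numbers for stronger inhibition), compound 1 `c1ccc(CO/N=C2/C(c3c[nH]c4ccccc34)=Nc3ccccc32)cc1` gives 21400 nM and compound 2 `FC(F)(F)c1ccc(CO/N=C2/C(c3c[nH]c4ccccc34)=Nc3ccccc32)cc1` gives 21200 nM, so compound 2 stands within the scatter of the only other number available. Compound 3 `Fc1ccc(CO/N=C2/C(c3c[nH]c4ccccc34)=Nc3ccccc32)c(Cl)c1` follows from compound 2 by one change: 2-chloro-4-fluorophenyl in place of 4-(trifluoromethyl)phenyl on a saturated chain carbon bound to an oxygen on an unsaturated carbon. That is 2-chloro-4-fluorophenyl in place of 4-(trifluoromethyl)phenyl on a saturated chain carbon bound to an oxygen on an unsaturated carbon. Within the data shown here, one measured step bears on it, trifluoromethyl in place of hydrogen on an aromatic carbon, which gave a 1.0-fold lower number from compound 1 to compound 2 (0.00 log units; within the scatter), within the scatter. Neither measured compound carries 2-chloro-4-fluorophenyl, so this evidence is thin. No shift beyond the scatter is expected, in either direction, and the estimated change is a 1.2-fold lower number from compound 2 to compound 3 (0.07 log units; within the scatter). For compound 3 the expected value is 18000 nM, with an estimated range of 8000 nM to 35000 nM.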

Compound 3, half-maximal inhibitory concentration: 19500 nM
Compound 3: middle estimate off by 1.1-fold (0.03 log units), on the low side; the range from low to high includes it.
By their numbers in this assay, from the lowest: compounds 3, 2 and 1 (each within the scatter of the next).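

In this assay the step to 2-chloro-4-fluorophenyl reads as a 1.1-fold lower number from compound 2 to compound 3 (0.04 log units; within the scatter) and, against the unsubstituted phenyl, as a 1.1-fold lower number from compound 1 to compound 3 (0.04 log units; within the scatter) and neither step lies beyond the scatter. Among these compounds, the earlier pair covered only a single trifluoromethyl change on the ring, whereas this result extends the flat picture at this position, on a saturated chain carbon bound to an oxygen on an unsaturated carbon, to a ring carrying both chlorine and fluorine. Nothing available accounts for this flat response.

The three aryl groups leave open whether any change at this position can move the number beyond the scatter. An amine or a carboxylic acid on the ring, or a longer chain in place of the aryl group, could test this.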